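A few compounds are considered here, and "the series" means these few. Any claim that something is new, unique, unknown or untested is made for them only; others in the source may bear on it.

Notes on the series, all read in a functional assay on A549 cells (Homo sapiens) for inhibition, read by MTT assay, with a stated time of 72 h (a higher number here means a weaker inhibitor, a lower number a stronger inhibitor), as the measure. Compound 1 (`COc1cc(O)cc(O)c1C(=O)/C=C/c1ccc(O)c(O)c1`) comes in at 11800 nM and compound 2 (`COc1cc(O)cc(O)c1C(=O)/C=C/c1ccc(Cl)cc1`) at 18200 nM on this measure. Compound 3 (`COc1cc(/C=C/C(=O)c2c(OC)cc(OC)cc2OC)cc(OC)c1`) gives 10100 nM here and stands within the scatter of both other compounds, so these numbers do not rank the three. Going by the values given here, no two measured compounds differ in one place only, which leaves no single change read directly so far.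

Compound 4 (`COc1cc(OC)c(C(=O)/C=C/c2cc(OC)c(OC)c(OC)c2)c(OC)c1`) differs from compound 3 by one change: methoxy in place of hydrogen on an aromatic carbon with methoxy in place of hydrogen on an aromatic carbon, ortho to two methoxy groups and para to a large group.

Compound 1 at 11800 nM and compound 3 at 10100 nM in this assay with different substitution remain within the scatter of each other, so no shift beyond the scatter is expected. The expected move is small, a 1.1-fold lower number from compound 3 to compound 4 (0.05 log units; within the scatter) as estimated. For compound 4 the estimate is 9000 nM with an expected range from 4000 nM to 20000 nM in this assay.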

Compound 4, half-maximal inhibitory concentration: 22300 nM
Beside the measured number, compound 4's estimate is 2.5-fold (0.39 log units) below it; the whole stated range lies below it.
By their numbers in this assay, from the lowest: compounds 3, 1, 2 and 4 (each within the scatter of the next, the first and the last beyond it).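

In this assay, going by these compounds alone, methoxy in place of hydrogen on an aromatic carbon, ortho to two methoxy groups and para to a large group, gives a 2.2-fold higher number from compound 3 to compound 4 (0.34 log units; beyond the scatter) and is the first single change that can be read directly. At this position, the added methoxy weakens inhibition modestly, so the ring carbon is not indifferent to substitution in this pair. No available evidence accounts for the shift.

Open, from the compounds shown here alone, is whether an amine or a carboxylic acid on the same aromatic carbon would move the number as methoxy does, or in the opposite direction. Also open, going by these compounds, is whether methoxy in place of hydrogen carries the same step on the core of compound 1 or the core of compound 2.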